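A few compounds are considered here, and "the series" means these few. Any claim that something is new, unique, unknown or untested is made for them only; others in the source may bear on it.

Of the compounds shown here, three built on a shared core have been measured in a functional assay on the whole organism (strain albino) for inhibition, with Rattus norvegicus as the target, read by paw edema, with stated times of 1 h and 4 h, at a dose of 200 mg/kg by the oral route; on this read-out higher numbers stand for more inhibition at the one dose given (going by the name of the read-out) and lower numbers for less inhibition. Compound 1 `O=c1oc2ccccc2cc1C1=NN(c2ccccc2)[C@@H](c2ccc(Cl)cc2Cl)C1` gives 67.5% in this assay. Compound 2 `CN(C)c1ccc([C@H]2CC(c3cc4ccccc4oc3=O)=NN2c2ccccc2)cc1` gives 40.1%, and compound 3 `O=c1oc2ccccc2cc1C1=NN(c2ccccc2)[C@@H](c2cccc([N+](=O)[O-])c2)C1` gives 31.2%. Compound 3 stands lowest of the three numbers: the step of a number 8.9 percentage points lower from compound 2 to compound 3 (within the scatter) lies within the scatter, while the step of a number 36.3 percentage points lower from compound 1 to compound 3 (beyond the scatter) lies beyond it. Compound 4 `Cc1ccc([C@H]2CC(c3cc4ccccc4oc3=O)=NN2c2ccccc2)cc1` has not yet been measured in this assay. It differs from compound 3 in one place: 4-methylphenyl in place of 3-nitrophenyl on a saturated ring carbon. Among the measured compounds shown here, no measured step concerns 4-methylphenyl, so any expectation rests only on what the three measured steps show. The step of a number 36.3 percentage points lower from compound 1 to compound 3 (beyond the scatter) shows that the group on the saturated ring carbon can move the result by a large amount, whereas the step of a number 8.9 percentage points lower from compound 2 to compound 3 (within the scatter) shows that two different groups in that place can also give numbers within the scatter of one another. For the measured compounds named here, with compound 1 as the only high number and compounds 2 and 3 sitting close together at the low end, a moderate rise is expected for compound 4, estimated as a number 13.8 percentage points higher from compound 3 to compound 4 (beyond the scatter). Compound 4 is thus expected to give 45% in this assay, with a likely range from 28% to 62%.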

Compound 4, a percentage reported as inhibition, in the whole organism at one dose (the size of the read-out at that dose, not a potency): 38%
The estimate for compound 4 lay 7 percentage points above the measured number; low and high end bracket the measured number.
By their numbers in this assay, from the lowest: compounds 3, 4 and 2 (each within the scatter of the next); then compound 1.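

In this assay, exchanging 3-nitrophenyl for 4-methylphenyl on the saturated ring carbon gives a number 6.8 percentage points higher from compound 3 to compound 4 (within the scatter), and methyl in place of dimethylamino on an aromatic carbon gives a number 2.1 percentage points lower from compound 2 to compound 4 (within the scatter), so a group made of carbon alone sits level with the nitro-bearing and dimethylamino-bearing groups at this position. Compound 1 now stands apart from three different groups rather than two, with 4-methylphenyl in place of 2,4-dichlorophenyl giving a number 29.5 percentage points lower from compound 1 to compound 4 (beyond the scatter), and its 2,4-dichlorophenyl group is the only one of the four that gives a high number. Nothing shown here offers a reason why these three groups fall together or why 2,4-dichlorophenyl stands apart.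

The compounds shown leave open whether the high number of compound 1 needs both chlorine atoms, which a phenyl group carrying a single chlorine atom, or a plain phenyl group, on the saturated ring carbon would address. They also leave open how a carboxylic acid or a primary amine on that aromatic ring would read, and whether the phenyl group on the neighbouring ring atom can be exchanged without loss.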